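The compounds below may be only part of what the source reports. "The series", "measured", "known", "first", "only" and "open" are said of these compounds alone.

Measured so far in an assay on membranes from CHO cells for displacement of a labelled ligand from adenosine receptor A1 (Homo sapiens), read by scintillation counting, with a stated time of 60 min, tested at 1 uM; on this read-out higher numbers stand for more inhibition at the one concentration tested (going by the name of the read-out) and lower numbers for less inhibition:

compound 1, `CC1=C(C(N)=O)C(c2ccoc2)NC(=O)N1`, gives 1%
compound 2, `CC1=C(C(N)=O)C(c2ccsc2)NC(=O)N1`, gives 2%
compound 3, `CCC(CC)OC(=O)C1=C(C)NC(=O)NC1c1ccoc1`, gives 17%

On these three numbers compound 2 stands second highest. Its nearest neighbour is compound 1: the step of a number 1 percentage points higher from compound 1 to compound 2 (within the scatter), so the two sit together. Among the compounds with values here, the only number clearly away from it is that of compound 3, whose value and that of compound 2 differ by more than the scatter allows.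

The next compound is compound 4, `CC1=C(C(=O)OC2CCCC2)C(c2ccsc2)NC(=O)N1`. Against compound 2 the change is cyclopentyloxy in place of amino on a carbonyl carbon.

The measured step that bears on this change is the one on the furan-bearing core, a number 16 percentage points higher from compound 1 to compound 3 (beyond the scatter). That step and the change from compound 2 to compound 4 both exchange the amino on the carbonyl carbon for an ether-linked carbon group; they differ in what that carbon group is, and in the ring on the saturated carbon, where the step of a number 1 percentage points higher from compound 1 to compound 2 (within the scatter) showed no effect beyond the scatter. Nothing measured separates cyclopentyloxy from (pentan-3-yl)oxy, so the size of the ester effect is taken over as it stands, with widened uncertainty.

In this assay compound 4 is therefore expected to rise by a number 14 percentage points higher from compound 2 to compound 4 (beyond the scatter). The estimate for compound 4 is 16%, in the range 4% to 32%.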

Compound 4, a percentage reported as inhibition, at one concentration (the size of the read-out at that concentration, not a potency): 5%
Estimate against measurement, compound 4: 11 percentage points above, within the range that was stated.
By their numbers in this assay, from the lowest: compounds 1, 2 and 4 (each within the scatter of the next); then compound 3.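

The step in this assay is a number 3 percentage points higher from compound 2 to compound 4 (within the scatter) for cyclopentyloxy in place of amino on a carbonyl carbon, so on the thiophen-3-yl compounds this exchange does not move the number beyond the scatter. The earlier step of a number 16 percentage points higher from compound 1 to compound 3 (beyond the scatter) on the furan-3-yl compounds, with (pentan-3-yl)oxy entering at the same place, therefore cannot be read as a general effect of replacing amino with an ether-linked carbon group. Nothing at hand explains why the two steps part.

The two steps differ in both the entering group and the ring on the saturated carbon, and the compounds shown do not separate these two changes; that would take one ester group carried on both rings. They also leave open how a carboxylic acid, a methylamino group or a longer chain such as hexyloxy on the same carbonyl carbon would read in this assay on either ring.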